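Thiophen-3-yl for pyridin-4-yl on the shared core

The compounds below may be only part of what the source reports. "The series", "measured", "known", "first", "only" and "open" are said of these compounds alone.

Among the measured compounds shown here, in a functional assay on MCF7 cells (Homo sapiens) for antiproliferative activity, read by MTT assay, with a stated time of 48 h (on this read-out lower numbers stand for stronger inhibition and higher numbers for weaker inhibition), compound 2 `CC(=O)N1N=C(c2ccc3ccccc3c2)OC1c1ccncc1` gives 2.56 ug/mL, the lower of the two numbers measured so far. Compound 1 `CC(=O)N1N=C(c2ccc3ccccc3c2)OC1c1ccccc1[N+](=O)[O-]` gives 18.2 ug/mL, the nearest and only comparison.

The next change is compound 3 `CC(=O)N1N=C(c2ccc3ccccc3c2)OC1c1ccsc1`, with thiophen-3-yl in place of pyridin-4-yl on a saturated ring carbon. For the measured compounds named here, one measured step bears on this: a 7.1-fold lower number from compound 1 to compound 2 (0.85 log units; beyond the scatter), beyond the scatter and modest in size, with pyridin-4-yl in place of 2-nitrophenyl at the same place. Going by the values given here, it shows that exchanging the group on this carbon can move the number in this assay, but no compound with a thiophen-3-yl group has been measured, so its direction here is not established. Among the compounds with values here, since compound 2 holds the lowest number so far at 2.56 ug/mL, a smaller move towards higher numbers is the working expectation. The expected step is a 2.1-fold higher number from compound 2 to compound 3 (0.33 log units; beyond the scatter). Compound 3 is estimated at 5.5 ug/mL, with an expected range of 1.8 ug/mL to 16 ug/mL.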

Compound 3, half-maximal inhibitory concentration: 7.98 ug/mL
Compound 3: the middle estimate sits 1.5-fold (0.16 log units) below what was measured; the range from low to high includes it.
By their numbers in this assay, from the lowest: compound 2; then compound 3; then compound 1.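

The position now holds three aromatic groups, and the step of a 3.1-fold higher number from compound 2 to compound 3 (0.49 log units; beyond the scatter) shows that replacing one aromatic ring bearing a single hetero atom with another, six-membered giving way to five-membered, still moves the number in this assay beyond the scatter. Against the 2-nitrophenyl group the thiophen-3-yl group keeps part of the advantage, with a 2.3-fold lower number from compound 1 to compound 3 (0.36 log units; beyond the scatter) as the step, so the three compounds stand apart and pyridin-4-yl stays the group with the lowest number. No supporting data accompany these numbers, so the order of the three groups stays a description and has no explanation here.

With only these three groups at this carbon, ring size and the identity of the hetero atom cannot be separated; an unsubstituted phenyl ring, a pyridin-3-yl group and a thiophen-2-yl group would each bear on that question. Also open, going by these compounds, is how the number responds to a group that is not an aromatic ring on this carbon, such as an amine or a short alkyl chain.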